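Adding an Isobutyl Group to Compound 3

The compounds below may be only part of what the source reports. "The series", "measured", "known", "first", "only" and "open" are said of these compounds alone.

Compound 1 `Cc1ccc(S(=O)(=O)N2CCC(Br)CC2)cc1`: in a functional assay on A2780 cells (Homo sapiens) for antiproliferative activity, read by sulforhodamine B assay, with a stated time of 48 h (on this read-out higher numbers stand for weaker inhibition of growth and lower numbers for stronger inhibition of growth), it gives > 100000 nM, which is a limit of the assay rather than a number.
Compound 2 `Cc1ccc(S(=O)(=O)N2CC[C@@H](Br)C[C@@H]2CC(C)C)cc1`: 39000 nM
Compound 3 `Cc1ccc(S(=O)(=O)N2CC=C(Cl)CC2)cc1`: > 100000 nM, again a limit of the assay, not a number.

Compound 3 therefore sits at the limit of > 100000 nM in this assay, at which 2 of the 3 values shown sit. Compound 4 `Cc1ccc(S(=O)(=O)N2CCC(Cl)=CC2CC(C)C)cc1` differs from it by isobutyl in place of hydrogen on a saturated ring carbon. Within the data shown here, the one measured step of this kind, an at least 2.5-fold lower number from compound 1 to compound 2 (0.40 log units; beyond the scatter), was made on a saturated ring and gave an at least modest gain. The same change on compound 3 is expected to behave alike, so the step of an at least 2.5-fold lower number from compound 3 to compound 4 (0.39 log units; beyond the scatter) is estimated to be a modest fall in the number. Compound 4 is thus expected to give about 40000 nM, in a range from 15000 nM to 110000 nM.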

Compound 4, concentration for 50% growth inhibition: 35000 nM
Compound 4: the middle estimate sits 1.1-fold (0.06 log units) above what was measured; measured number inside the range.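

In this assay, isobutyl on a saturated ring carbon next to the ring nitrogen lowers the number on a second core as well, with an at least 2.8-fold lower number from compound 3 to compound 4 (0.45 log units; beyond the scatter). The gain is therefore not confined to the core of compound 1. Both steps start from a limit of the assay, so their sizes can be compared only loosely: the same change on two cores in this assay, an at least 2.5-fold lower number (0.40 log units; beyond the scatter) from compound 1 to compound 2 and an at least 2.8-fold lower number (0.45 log units; beyond the scatter) from compound 3 to compound 4; the limit leaves it open whether they differ

On these data alone, whether a shorter chain such as methyl, a longer chain or an amine at this place would change growth inhibition more remains open. So does whether isobutyl would lower the number on other cores.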